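Removing the Ring Methyl: Compound 3 to Compound 4

This account rests on a few compounds, and the source may have more. Where it says the series, first, only, none or still open, it means among the compounds named here.

Of the compounds shown here, three have been measured so far in a functional assay on MCF7 cells (Homo sapiens) for cytotoxicity, read by MTT assay, with a stated time of 72 h, tested at 10 uM; on this read-out higher numbers stand for more inhibition of growth at the one concentration tested and lower numbers for less inhibition of growth. Compound 1 `N/C(=N\NC(=S)N1CCOCC1)c1ccc(F)cn1` gives 39.5%, compound 2 `N/C(=N\NC(=S)N1CCOCC1)c1ccccn1` gives 66.7%, and compound 3 `Cc1ccnc(/C(N)=N/NC(=S)N2CCN(c3ccccn3)CC2)c1` gives 32.1%. Compound 3 therefore stands lowest of the three numbers; its gap to compound 1 lies within the scatter, while its gap to compound 2 lies beyond it. For the measured compounds named here, the only one-place step measured is a number 27.2 percentage points higher from compound 1 to compound 2 (beyond the scatter), a modest rise on removing a ring substituent.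

Compound 4 `N/C(=N\NC(=S)N1CCN(c2ccccn2)CC1)c1ccccn1`, not yet measured, differs from compound 3 as follows: hydrogen in place of methyl on an aromatic carbon. Going by the values given here, no measured pair removes a methyl in this position, so the fluoro-to-hydrogen step is the nearest guide, and the difference between the two compounds lies in a group of a different kind. Compound 2 carries hydrogen at the same carbon but also a different amine, so its value bears on compound 4 only loosely. On this basis a rise in this assay is expected, smaller and less certain than the measured step: the expected step is a number 12.9 percentage points higher from compound 3 to compound 4 (beyond the scatter). Compound 4 is estimated at 45%, with a range from 25% to 65%.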

Compound 4, percent growth inhibition at one concentration: 46.4%
The estimate for compound 4 lay 1.4 percentage points below the measured number; low and high end bracket the measured number.
By their numbers in this assay, from the lowest: compounds 3, 1 and 4 (each within the scatter of the next, the first and the last beyond it); then compound 2.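

In this assay, the change from 4-methylpyridin-2-yl to pyridin-2-yl gives a number 14.3 percentage points higher from compound 3 to compound 4 (beyond the scatter), the first measured sign that this aromatic carbon, opposite the ring nitrogen, is sensitive to a methyl group. The earlier step, a number 27.2 percentage points higher from compound 1 to compound 2 (beyond the scatter), concerned fluoro and a different amine, so a rise on going to hydrogen now appears with two different substituents and two different amines; neither measured pair goes against this, although two pairs establish no general rule. No measurement available here bears on the reason for the rise.

On these data alone, whether hydrogen is favoured at this carbon over substituents in general remains open, since a methoxy group, a chlorine atom, an amine or a longer chain such as ethyl could fall on either side of the methyl and hydrogen pair. As far as these compounds go, it is also open whether adding methyl at this carbon to compound 2 would lower the number as its removal from compound 3 raised it, and the single tested concentration says nothing of the full concentration response.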